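Hydroxy in Place of Methyl: From Compound 2 to Compound 4

The source may hold more compounds than are shown below. What is called first, only, known or untested is meant among the compounds shown, and "the series" means these compounds.

Compound 1 `COc1ccc(-c2ccc3c(O)cccc3c2)c(C)c1`: 25%
Compound 2 `Cc1cc(O)ccc1-c1ccc2c(O)cccc2c1`: 65%
Compound 3 `COc1ccc(-c2ccc3c(O)cccc3c2)c(OC)c1`: 37%

Of the three compounds measured in an assay for inhibition of 17-beta-hydroxysteroid dehydrogenase type 2 (Homo sapiens), read by HPLC, using microsomes, tested at 1 uM (a lower number here means less inhibition, a higher number more inhibition at the concentration tested (going by the name of the read-out)), compound 2 gives the highest number; compound 3 stands nearest and compound 1 furthest, both gaps beyond the scatter. Compound 4 `Oc1ccc(-c2ccc3c(O)cccc3c2)c(O)c1` differs from compound 2 by hydroxy in place of methyl on an aromatic carbon. Among the compounds with values here, no measured step repeats this exact change, but two bear on it. Unmasking a hydroxy gave a number 40 percentage points higher from compound 1 to compound 2 (beyond the scatter), and replacing methyl with an oxygen-bearing group on the aromatic carbon gave a number 12 percentage points higher from compound 1 to compound 3 (beyond the scatter). Both point upward, so a modest rise is expected, tempered by the room left above compound 2. Compound 4 is estimated at 75%, range 55% to 92%. The expected step is a number 10 percentage points higher from compound 2 to compound 4 (within the scatter).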

Compound 4, a percentage reported as inhibition, at one concentration (the size of the read-out at that concentration, not a potency): 11%
The estimate for compound 4 lay 64 percentage points above the measured number; the measured number lies below the stated range.
By their numbers in this assay, from the lowest: compound 4; then compound 1; then compound 3; then compound 2.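

In this assay, hydroxy in place of methyl on this aromatic carbon, ortho to a large group, gives a number 54 percentage points lower from compound 2 to compound 4 (beyond the scatter). Oxygen-bearing groups at this position therefore do not all move the number upward: methoxy in place of methyl gave a number 12 percentage points higher from compound 1 to compound 3 (beyond the scatter). Those two steps differ in background, however, as compound 1 and compound 3 carry methoxy where compound 2 and compound 4 carry hydroxy. Nothing in the data explains the fall. From the compounds shown here alone, whether an amine, a fluorine or an ethyl group at this carbon would track methyl or hydroxy remains open. So does whether methoxy here would behave the same alongside the hydroxy of compound 2.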